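One stereocentre left undrawn

The source may hold more compounds than are shown below. What is called first, only, known or untested is meant among the compounds shown, and "the series" means these compounds.

Measured in an ADME assay on MT4 cells (Homo sapiens) for cytotoxicity, read by MTT assay, with a stated time of 5 days; a lower number here means that less compound is tolerated, a higher number that more compound is tolerated:
- compound 1 `Cc1c(N)nc(Nc2ccc(C#N)cc2)nc1[C@H](C)c1c(F)cccc1F`: 31000 nM
- compound 2 `CCCN(C)c1nc([C@@H](C)c2c(F)cccc2F)c(C)c(=O)[nH]1`: > 78000 nM

In this assay compound 2 stands at > 78000 nM, which is a limit of the assay and not a number. Compound 3 `CCCN(C)c1nc(C(C)c2c(F)cccc2F)c(C)c(=O)[nH]1` is still to be measured. It differs from compound 2 only in how one stereocentre is drawn: the two compounds have the same atoms and bonds; at least one stereo element is drawn with a configuration in one of them and without one in the other: 1 of 1 stereo elements differ; a stereocentre at a saturated chain carbon is drawn S in compound 2 and without a configuration in compound 3. Within the data shown here, no measured pair shows a change of this kind. The expected step, a step that the limit leaves unreadable from compound 2 to compound 3, is none beyond the scatter in this assay, in either direction. For compound 3 the estimated value is 90000 nM, with an expected range from 45000 nM to 180000 nM.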

Compound 3, half-maximal cytotoxic concentration: > 78000 nM
Compound 3 ended at the assay's limit (the forecaster's own chance of this, stated with the estimate: 65%); the middle value does not contradict the limit.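

Compound 2 and compound 3 both stand at a limit of this assay, not at a number, so no step between them can be read: the limit of > 78000 nM in this assay, at which 2 of the 3 values shown sit.

On these data alone, whether the configuration drawn at that stereocentre matters in this assay stays open.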